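This account rests on a few compounds, and the source may have more. Where it says the series, first, only, none or still open, it means among the compounds named here.

Measured so far:
Compound 1 `CC(=O)n1nc(N)c2c(-c3ccccc3)c(-c3ccccc3)nnc21`: > 100000 nM
Compound 2 `Nc1nn(CCOCCO)c2nnc(-c3ccccc3)c(-c3ccccc3)c12`: > 100000 nM

The test here is a functional assay on HeLa cells (Homo sapiens) for cytotoxicity; a higher number here means a weaker inhibitor, a lower number a stronger inhibitor. In it, compound 2 gives > 100000 nM, which is a limit of the assay and not a number. Compound 1 gives > 100000 nM, which is also a limit. The data so far therefore amount to the limit of > 100000 nM in this assay, at which 2 of the 2 values shown sit.

Compound 3 `Nc1nn(COCCO)c2nnc(-c3ccccc3)c(-c3ccccc3)c12` keeps the core of compound 2 and alters only the side chain, where 2-(2-hydroxyethoxy)ethyl gives way to (2-hydroxyethoxy)methyl: 2-hydroxyethoxy in place of (2-hydroxyethoxy)methyl on a saturated chain carbon bound to an aromatic nitrogen.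

Among the measured compounds shown here, the one measured step that bears on this change, made on the same aromatic nitrogen, is a step that the two limits leave unreadable from compound 1 to compound 2. It offers no size to carry over. With compound 2 at > 100000 nM, the expectation for compound 3 is no step beyond the usual scatter in this assay, and most likely another limit. The expected step is a step that the limit leaves unreadable from compound 2 to compound 3. For compound 3 the estimated value is 120000 nM, with an expected range from 50000 nM to 300000 nM.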

Compound 3, half-maximal inhibitory concentration: > 100000 nM
Compound 3 gave a limit, no number (the forecaster's own chance of this, stated with the estimate: 85%); the middle value lies beyond the limit too.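

In this assay compound 3 gives > 100000 nM and this is a limit of the assay, not a number. No step can be read among compound 1, compound 2 and compound 3, because all three stop at the same point: the limit of > 100000 nM in this assay, at which 3 of the 3 values shown sit. On these data alone, how strongly any of them acts on these cells, and whether changing the side chain on the aromatic nitrogen matters at all, stays open.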